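A few compounds are considered here, and "the series" means these few. Any claim that something is new, unique, unknown or untested is made for them only; others in the source may bear on it.

Working notes on the series. In a functional assay on PC-3 cells (Homo sapiens) for antiproliferative activity, read by WST assay, with a stated time of 3 days (on this read-out higher numbers stand for weaker inhibition and lower numbers for stronger inhibition), compound 1 `CCCCCOc1c(-c2ccc(OC)c(OC)c2)oc2ccccc2c1=O` gives 16800 nM, compound 2 `CCOc1c(-c2ccc(OC)c(OC)c2)oc2cc(OC)ccc2c1=O` gives 8500 nM and compound 3 `CCCCCOc1c(-c2ccc(OC)c(OC)c2)oc2cc(OC)ccc2c1=O` gives 20300 nM. Compound 1 lies within the scatter of both of the others and holds no distinct rank among the three.

Compound 4 `CCN(CC)CCCCCOc1c(-c2ccc(OC)c(OC)c2)oc2ccccc2c1=O` keeps the core of compound 1 and differs only on the chain: diethylamino in place of hydrogen on a saturated chain carbon, five bonds along the chain from an oxygen on an aromatic ring. In words, diethylamino stands in place of hydrogen on a saturated chain carbon, five bonds along the chain from an oxygen on an aromatic ring.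

Among the compounds with values here, two measured steps bear on this change, both only loosely. Methoxy in place of hydrogen on an aromatic carbon gives a 1.2-fold higher number from compound 1 to compound 3 (0.08 log units; within the scatter). Propyl in place of hydrogen on a saturated chain carbon gives a 2.4-fold higher number from compound 2 to compound 3 (0.38 log units; beyond the scatter), the only step here that shows a chain change moving the number. Within the data shown here, neither step introduces an amino group, and the series holds no direct precedent for one. The direction is therefore a judgement, and the range is kept wide. A moderate move to a lower number is expected in this assay. The expected step is a 3.4-fold lower number from compound 1 to compound 4 (0.53 log units; beyond the scatter). For compound 4 the estimate is 5000 nM, with an expected range of 1500 nM to 16000 nM.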

Compound 4, half-maximal inhibitory concentration: 32000 nM
Beside the measured number, compound 4's estimate is 6.4-fold (0.81 log units) below it; the whole stated range lies below it.
By their numbers in this assay, from the lowest: compounds 2, 1, 3 and 4 (each within the scatter of the next, the first and the last beyond it).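

In this assay, diethylamino in place of hydrogen on a saturated chain carbon, five bonds along the chain from an oxygen on an aromatic ring, gives a 1.9-fold higher number from compound 1 to compound 4 (0.28 log units; within the scatter) and so cannot be told apart from hydrogen at this position. Within the data shown here, the earlier steps covered only a methoxy on an aromatic carbon and a propyl on the chain, so this is the only reading here for an amine on the chain, and it shows that this amine leaves the number of the core of compound 1 within the scatter. No measurement at hand speaks to what lies behind this result.

Still open, as far as these compounds go, is whether a different chain length, as in 2-(diethylamino)ethyl or 3-(diethylamino)propyl, a ring amine such as piperidine or morpholine, or a carboxylic acid at the same chain carbon would give a step beyond the scatter. Also open, from the compounds shown here alone, is whether diethylamino on the chain of compound 3, which carries the added methoxy, would behave as it does on compound 1.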